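Working notes: hydroxy for chloro, compound 2 to compound 4

This account rests on a few compounds, and the source may have more. Where it says the series, first, only, none or still open, it means among the compounds named here.

Measured in a functional assay, with a stated time of 10 min; a lower number here means a stronger inhibitor, a higher number a weaker inhibitor:
compound 1 `Cn1c(NN)nc(-c2cccc(O)c2O)c(C#N)c1=O` gives 29 ug/mL
compound 2 `CCOC(=O)c1cnn(-c2nc(-c3ccccc3Cl)c(C#N)c(=O)n2C)c1N` gives 98 ug/mL
compound 3 `Cn1c(NN)nc(-c2ccc(Cl)cc2)c(C#N)c1=O` gives 41 ug/mL

Compound 2 carries the highest number of the three in this assay; its steps to compound 3 and to compound 1 both lie beyond the scatter, so it is the weakest inhibitor shown. Compound 4 `CCOC(=O)c1cnn(-c2nc(-c3ccccc3O)c(C#N)c(=O)n2C)c1N` differs from compound 2 in one place: hydroxy in place of chloro on an aromatic carbon. Within the data shown here, no measured pair shows this change on its own; compound 1, which carries hydroxy groups, and compound 3, which carries chloro, differ in more than one place and cannot be read as a step. In this assay a small move toward a lower number, within the scatter, is expected, so that a 1.3-fold lower number from compound 2 to compound 4 (0.12 log units; within the scatter) is the estimated step. Compound 4 is therefore estimated at 75 ug/mL, in the range 40 ug/mL to 140 ug/mL.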

Compound 4, half-maximal inhibitory concentration: 58 ug/mL
For compound 4 the middle estimate is 1.3-fold (0.11 log units) above the measured one; the range from low to high includes it.
By their numbers in this assay, from the lowest: compounds 1, 3, 4 and 2 (each within the scatter of the next, the first and the last beyond it).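

In this assay, among these compounds, hydroxy in place of chloro gives a 1.7-fold lower number from compound 2 to compound 4 (0.23 log units; within the scatter), the first step that can be read on its own. On this aromatic carbon, ortho to a large group, 2-chlorophenyl and 2-hydroxyphenyl therefore cannot be told apart in this read-out, although the change adds a hydrogen-bond donor. No measurement is available that would explain this step.

Still open, going by these compounds, is whether an amine or a methoxy group on this carbon would move the number beyond the scatter. Also open, on these data alone, is whether the same exchange reads alike on the core of compound 3.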